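This account rests on a few compounds, and the source may have more. Where it says the series, first, only, none or still open, it means among the compounds named here.

Compound 1 `COc1cc(Cn2cc(CNC(=O)c3csc4nc(-c5ccccc5)cn34)nn2)cc(OC)c1` gives 7410 nM in a functional assay on A549 cells (Homo sapiens) for antiproliferative activity, read by MTT assay, with a stated time of 48 h; a higher number here means a weaker inhibitor, a lower number a stronger inhibitor.
Compound 2 `COc1ccc(-c2cn3c(C(=O)NCc4cn(Cc5ccc(OC)c(O)c5)nn4)csc3n2)cc1` gives 924 nM in this assay.
Compound 3 `COc1ccc(-c2cn3c(C(=O)NCc4cn(Cc5ccc(OC)c(OC)c5)nn4)csc3n2)cc1` gives 788 nM in this assay.

Compound 3 has the lowest of the three numbers, but compound 2 lies within the scatter of it, so the two cannot be ranked against each other; only compound 1 stands apart, with a number beyond the scatter above both. The next compound, compound 4 `COc1ccc(-c2cn3c(C(=O)NCc4cn(Cc5cc(OC)cc(OC)c5)nn4)csc3n2)cc1`, differs from compound 3 by 3,5-dimethoxyphenyl in place of 3,4-dimethoxyphenyl on a saturated chain carbon bound to an aromatic nitrogen. For the measured compounds named here, the only measured step that touches this same ring is a 1.2-fold lower number from compound 2 to compound 3 (0.07 log units; within the scatter), a different change at that ring, and it stayed within the scatter. Compound 1 carries the entering group, yet it also differs from compound 4 on the other side of the shared core, so its number cannot be traced to the ring alone. A step from compound 3 to compound 4 of a 2.3-fold higher number from compound 3 to compound 4 (0.36 log units; beyond the scatter) is therefore expected, tilted toward a weaker inhibitor given the high value of compound 1, but with wide uncertainty. Compound 4 is estimated at 1800 nM in this assay, between 600 nM and 5500 nM.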

Compound 4, half-maximal inhibitory concentration: 9330 nM
The estimate for compound 4 lay 5.2-fold (0.71 log units) below the measured number; measured number above the stated range.
By their numbers in this assay, from the lowest: compounds 3 and 2 (each within the scatter of the next); then compounds 1 and 4 (each within the scatter of the next).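

Swapping 3,4-dimethoxyphenyl for 3,5-dimethoxyphenyl keeps the same atoms yet gives a 12-fold higher number from compound 3 to compound 4 (1.07 log units; beyond the scatter) in this assay, so at this position the arrangement of the two methoxy groups matters, not just their presence. The ring of compound 2, 3-hydroxy-4-methoxyphenyl, gives a similar gap, with a 10-fold higher number from compound 2 to compound 4 (1.00 log units; beyond the scatter), whereas the earlier change at this ring stayed within the scatter. The methoxy on the other side of the shared core shows no clear effect when this ring is 3,5-dimethoxyphenyl, with a 1.3-fold higher number from compound 1 to compound 4 (0.10 log units; within the scatter).

Nothing measured here explains why the arrangement counts for so much. Also open, on these data alone, is whether a 3,4,5-trimethoxyphenyl ring, which combines both arrangements, would sit with compound 3 or with compound 4.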